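Swapping methylsulfanyl for methyl on a furan-3-yl compound

A few compounds are considered here, and "the series" means these few. Any claim that something is new, unique, unknown or untested is made for them only; others in the source may bear on it.

Compound 1 `CSc1ncnc2c1c(-c1ccoc1)cn2[C@@H]1O[C@H](CO)[C@@H](O)[C@H]1O` with 3250 nM
Compound 2 `CSc1ncnc2c1c(-c1cccs1)cn2[C@@H]1O[C@H](CO)[C@@H](O)[C@H]1O` with > 20000 nM (a limit of the assay)
Compound 3 `C#Cc1cn([C@@H]2O[C@H](CO)[C@@H](O)[C@H]2O)c2ncnc(SC)c12` with 70 nM

In a functional assay on K562 cells (Homo sapiens), read by MTT assay, with a stated time of 72 h (a higher number here means a weaker inhibitor, a lower number a stronger inhibitor), compound 1 gives 3250 nM as the higher of the two actual numbers, and compound 3 gives 70 nM as the lower. The value of compound 2 is a limit of the assay, > 20000 nM and not a number.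

Compound 4 `Cc1ncnc2c1c(-c1ccoc1)cn2[C@@H]1O[C@H](CO)[C@@H](O)[C@H]1O` differs from compound 1 as follows: methyl in place of methylsulfanyl on an aromatic carbon and so carries methyl in place of methylsulfanyl on an aromatic carbon, while keeping the furan-3-yl group. The measured steps of an at least 6.1-fold higher number from compound 1 to compound 2 (0.78 log units; beyond the scatter) and a 46-fold lower number from compound 1 to compound 3 (1.67 log units; beyond the scatter) are at least modest and large, but both replace the furan-3-yl group and leave methylsulfanyl untouched. Within the data shown here, no measured step therefore sizes this change directly, and no shift beyond the scatter is expected in this assay in either direction, though the uncertainty is wide. The expected step is a 1.1-fold lower number from compound 1 to compound 4 (0.03 log units; within the scatter) and stays within the scatter. Compound 4 is estimated at 3000 nM with an expected range of 500 nM to 20000 nM around that figure.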

Compound 4, half-maximal inhibitory concentration: > 20000 nM
Compound 4: no number, only a limit; the forecaster's own chance of this, stated with the estimate: 20%; middle value at least 6.6-fold (0.82 log units) from the limit.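

In this assay, the result for compound 4 is a limit of the assay and not a number. Among these compounds, it is still the first measured change at the methylsulfanyl group with the furan-3-yl group kept: methyl in its place gives an at least 6.1-fold higher number from compound 1 to compound 4 (0.78 log units; beyond the scatter), so this exchange does not leave the result within the scatter. That step gives only a minimum size, since the read-out of compound 4 stops at a limit: the limit of > 20000 nM in this assay, at which 2 of the 4 values shown sit.

The compounds shown carry this change only alongside the furan-3-yl group, so whether it holds beside the ethynyl group of compound 3, at 70 nM, stays open. They also leave open how an amine or a longer chain such as ethylsulfanyl would behave on this aromatic carbon.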